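The compounds below may be only part of what the source reports. "The series", "measured", "known", "first", "only" and "open" are said of these compounds alone.

Compound 1 `O=C(OC1(C(=O)Nc2ccc([N+](=O)[O-])cc2)CCCCC1)c1ccc(Cl)cc1` gives 15 nM in a functional assay on MCF7 cells (Homo sapiens) for inhibition, read by MTT assay, with a stated time of 72 h; a lower number here means a stronger inhibitor, a higher number a weaker inhibitor. For the measured compounds named here, compound 2 `COc1ccc(C(=O)OC2(C(=O)Nc3ccc([N+](=O)[O-])cc3)CCCCC2)cc1` gives 41.2 nM in this assay, the higher of the two numbers; the only measured step, a 2.7-fold higher number from compound 1 to compound 2 (0.44 log units; beyond the scatter), is modest. Compound 3 `O=C(OC1(C(=O)Nc2ccc([N+](=O)[O-])cc2)CCCCC1)c1ccccc1I` differs from compound 2 by 2-iodophenyl in place of 4-methoxyphenyl on a carbonyl carbon. Going by the values given here, that single step is the only guidance for this change, and it points toward recovery, because compound 1 with its chloro gave 15 nM and a halogen returns within the 2-iodophenyl. A modest step to a lower number is therefore expected, a 1.9-fold lower number from compound 2 to compound 3 (0.27 log units; within the scatter). Compound 3 is estimated at 22 nM, within a range from 8 nM to 60 nM.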

Compound 3, half-maximal inhibitory concentration: 619 nM
The estimate for compound 3 lay 28-fold (1.45 log units) below the measured number; the measured number lies above the stated range.
By their numbers in this assay, from the lowest: compound 1; then compound 2; then compound 3.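

In this assay the swap to 2-iodophenyl on this carbonyl carbon gives a 15-fold higher number from compound 2 to compound 3 (1.18 log units; beyond the scatter) and also a 41-fold higher number from compound 1 to compound 3 (1.62 log units; beyond the scatter), both far larger than the earlier step. A halogen on this aromatic ring therefore does not by itself guarantee a low number, and changes at this position can matter much more than the first pair suggested. Nothing measured here accounts for the rise. Still open, on these data alone, is whether the iodine or its place on the ring matters more; a 2-chlorophenyl or 4-iodophenyl group would separate the two.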